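Swapping the Aryl Amide Group of Compound 1

The source may hold more compounds than are shown below. What is called first, only, known or untested is meant among the compounds shown, and "the series" means these compounds.

Measured in a functional assay on K562 cells (Homo sapiens) for antiproliferative activity, read by MTT assay, with a stated time of 24 h; a higher number here means a weaker inhibitor, a lower number a stronger inhibitor:
- compound 1 `COC(=O)c1scc(-c2ccc(NC(=O)c3cccc(C(F)(F)F)c3)cc2)c1OC`: 6130 nM
- compound 2 `COC(=O)c1scc(-c2ccc(NC(=O)c3cccc(I)c3)cc2)c1OC`: 14700 nM
- compound 3 `COC(=O)c1scc(-c2ccc(NC(=O)c3ccc(C#N)nc3)cc2)c1OC`: "not determined" (no result reported)

Compound 1 holds the lower of the two numbers available in this assay, while compound 3 offers no number to compare. The next compound to be tested is compound 4 `COC(=O)c1scc(-c2ccc(NC(=O)c3ccc(OC)nc3)cc2)c1OC`, which keeps the core of compound 1 and changes a single group: 6-methoxypyridin-3-yl in place of 3-(trifluoromethyl)phenyl on a carbonyl carbon. Among the measured compounds shown here, only one measured step bears on this change: a 2.4-fold higher number from compound 1 to compound 2 (0.38 log units; beyond the scatter). For the measured compounds named here, that step is modest and replaces only one group on the aromatic ring, whereas compound 4 replaces the whole 3-(trifluoromethyl)phenyl, so it is a rough guide at best. Going by the values given here, with so little data, the direction is uncertain, but the one measured change away from compound 1 gave compound 2 at 14700 nM, so a higher number is the more likely outcome. An estimated 2.0-fold higher number from compound 1 to compound 4 (0.29 log units; within the scatter) is therefore expected. For compound 4 the estimate is 12000 nM, with an expected range from 4500 nM to 30000 nM.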

Compound 4, half-maximal inhibitory concentration: 18300 nM
Beside the measured number, compound 4's estimate is 1.5-fold (0.18 log units) below it; low and high end bracket the measured number.
By their numbers in this assay, from the lowest: compound 1; then compounds 2 and 4 (each within the scatter of the next).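

In this assay, the step of a 3.0-fold higher number from compound 1 to compound 4 (0.47 log units; beyond the scatter) shows that this place on the carbonyl carbon can take 6-methoxypyridin-3-yl, a ring with a hetero atom, in place of 3-(trifluoromethyl)phenyl and still give a measurable number, though not one that matches compound 1. The step of a 1.2-fold higher number from compound 2 to compound 4 (0.10 log units; within the scatter) means that compound 2 and compound 4 cannot be told apart, so two different replacements land at a similar level, and compound 1 keeps the lowest number, beyond the scatter of both. No evidence is available to explain these differences.

From the compounds shown here alone, whether the ring nitrogen or the methoxy group matters more for this step remains open. Also open, going by these compounds, is how an unsubstituted phenyl ring, or a ring carrying an amine or a carboxylic acid, would compare.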